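This account rests on a few compounds, and the source may have more. Where it says the series, first, only, none or still open, it means among the compounds named here.

Measured compounds:
Compound 1, `CCN(CC)S(=O)(=O)c1ccc(S(=O)(=O)N2CCC[C@@H](C(=O)N[C@H]3CC[C@H](OC)CC3)C2)cc1`, gives 2290 nM in a functional assay on MIA PaCa-2 cells (Homo sapiens) for inhibition, read by MTT assay, with a stated time of 3 days; on this read-out higher numbers stand for weaker inhibition and lower numbers for stronger inhibition.
Compound 2, `CCN(CC)S(=O)(=O)c1ccc(S(=O)(=O)N2CCC[C@@H](C(=O)N3CCC(C(F)(F)F)CC3)C2)cc1`, gives 110 nM in this assay.

Compound 2 has the lowest number of the two in this assay, and compound 1 sits far from it, as the step of a 21-fold lower number from compound 1 to compound 2 (1.32 log units; beyond the scatter) shows. Compound 3, `CCN(CC)S(=O)(=O)c1ccc(S(=O)(=O)N2CCC[C@@H](C(=O)N3CCS(=O)(=O)CC3)C2)cc1`, is not yet measured. It differs from compound 2 in one place: 1,1-dioxothiomorpholin-4-yl in place of 4-(trifluoromethyl)piperidin-1-yl on a carbonyl carbon.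

Within the data shown here, only one measured step exists, a 21-fold lower number from compound 1 to compound 2 (1.32 log units; beyond the scatter), and it does not match this change: it replaced a ring bearing an amino group on the carbonyl carbon with a 4-(trifluoromethyl)piperidin-1-yl, whereas the move to compound 3 keeps a ring nitrogen on the carbonyl carbon and swaps the ring itself. That step shows the group on the carbonyl carbon matters strongly, but it gives no direct guide to the 1,1-dioxothiomorpholin-4-yl. The estimate therefore rests on compound 2 alone, and compound 3 is expected to give a moderately higher number, a step of a 4.5-fold higher number from compound 2 to compound 3 (0.66 log units; beyond the scatter). The expected value for compound 3 in this assay is 500 nM, with a range from 120 nM to 2500 nM.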

Compound 3, half-maximal inhibitory concentration: 220 nM
Beside the measured number, compound 3's estimate is 2.3-fold (0.36 log units) above it; low and high end bracket the measured number.
By their numbers in this assay, from the lowest: compounds 2 and 3 (each within the scatter of the next); then compound 1.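

In this assay, the step of a 2.0-fold higher number from compound 2 to compound 3 (0.30 log units; within the scatter) shows that this position on the carbonyl carbon accepts two rather different rings without a change beyond the scatter: 4-(trifluoromethyl)piperidin-1-yl, with 0 hydrogen-bond acceptors, and 1,1-dioxothiomorpholin-4-yl, with 2. The step of a 10-fold lower number from compound 1 to compound 3 (1.02 log units; beyond the scatter) adds a second large gap from the (4-methoxycyclohexyl)amino compound, so among these three compounds a low number does not depend on the trifluoromethyl group or on the fluorine atoms that carry it. Nothing measured explains why these rings give such similar numbers or why both stand so far from compound 1.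

The compounds shown leave open whether the gap from compound 1 comes with having the ring nitrogen on the carbonyl carbon, since no compound keeps the (4-methoxycyclohexyl)amino group's ring while changing only that link. They also leave open how far this tolerance extends, for example whether an unsubstituted piperidin-1-yl, a morpholin-4-yl or a ring carrying a carboxylic acid would stay in the same range.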